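A Sulfur Ring Takes the Place of an Acetyl Chain

The compounds below may be only part of what the source reports. "The series", "measured", "known", "first", "only" and "open" are said of these compounds alone.

Among the measured compounds shown here, compound 2 `CC(=O)CC[C@]1(C(C)=O)C(=O)O[C@@H](OC(C)=O)[C@H]1C` holds the lower of the two numbers measured so far: in a functional assay on B16 cells (Mus musculus) for cytotoxicity, read by MTT assay (on this read-out higher numbers stand for weaker inhibition and lower numbers for stronger inhibition), compound 2 gives 7000 nM. Compound 1 `CC(=O)O[C@@H]1OC(=O)[C@](Cc2ccccc2)(C(C)=O)[C@@H]1C` gives 41000 nM in this assay; it carries a phenyl where compound 2 carries a 2-oxopropyl. For the measured compounds named here, the one measured step, a 5.9-fold lower number from compound 1 to compound 2 (0.77 log units; beyond the scatter), shows that the group on this carbon of the shared core can shift the read-out modestly. Compound 3 `CC(=O)O[C@@H]1OC(=O)[C@@](C(C)=O)(C2SCCCS2)[C@@H]1C` is the next candidate. Its change from compound 2 is a group of 6 heavy atoms (4 carbon, 2 sulfur; one six-membered non-aromatic ring with 2 hetero atoms) in place of a group of 5 heavy atoms (4 carbon, 1 oxygen; no ring), on a saturated ring carbon, that is, a closed ring holding sulfur replaces an open chain bearing a carbonyl. Going by the values given here, no measured step covers this exact swap; the step from phenyl to 2-oxopropyl is the only guide, and it ran from a ring toward a chain. Compound 3 again carries a ring group, so the guess leans the other way. For compound 3 a step back toward the higher number is expected, of the size a 2.9-fold higher number from compound 2 to compound 3 (0.46 log units; beyond the scatter), with wide uncertainty because the sulfur ring is not a phenyl. Compound 3 is estimated at 20000 nM, in a range from 5000 nM to 80000 nM.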

Compound 3, half-maximal inhibitory concentration: > 50000 nM
Compound 3 ended at the assay's limit (the forecaster's own chance of this, stated with the estimate: 5%); at least 2.5-fold (0.39 log units) between middle value and limit.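

In this assay compound 3 stands at a limit of the assay and not at a true number: the limit of > 50000 nM in this assay, at which 1 of the 3 values shown sits. The step from the chain compound can still be read in one direction: an at least 7.1-fold higher number from compound 2 to compound 3 (0.85 log units; beyond the scatter) when the sulfur ring enters and the 2-acetylethyl leaves, so on this saturated ring carbon the open chain with its carbonyl is, among the groups shown, the only one tied to the lower number. The other step, an at least 1.2-fold higher number from compound 1 to compound 3 (0.08 log units; that floor lies within the scatter), has a floor that does not separate the sulfur ring from the phenyl, so the two ring groups cannot be put in order, and both stay on the higher side of the chain.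

From the compounds shown here alone, what remains open is whether the lower number goes with the open chain as such or with the carbonyl it carries, and three compounds cannot settle that. A plain butyl chain on the same carbon, or a chain ending in an amine or a carboxylic acid, would help tell these two readings apart.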